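Three Inactive Amides and a Benzyl-for-Phenyl Swap

This account rests on a few compounds, and the source may have more. Where it says the series, first, only, none or still open, it means among the compounds named here.

Compound 1, `CS(=O)(=O)c1ccc(C(=O)N2CCC(C(=O)N(Cc3ccccc3)c3ccccc3)CC2)cc1[N+](=O)[O-]`, was tested in an assay on isolated protein for inhibition of vitamin D3 receptor (Homo sapiens), read by fluorescence polarization; a lower number here means a stronger inhibitor, a higher number a weaker inhibitor. In this assay compound 1 gives > 60000 nM, which is a limit of the assay rather than a number. Compound 2, `CCCN(C(=O)CN(C)C(=O)c1ccc(S(C)(=O)=O)c([N+](=O)[O-])c1)c1ccccc1`, gives > 60000 nM in this assay, again a limit. Compound 3, `CS(=O)(=O)c1ccc(C(=O)NCCCC(=O)N2Cc3ccccc3C2)cc1[N+](=O)[O-]`, likewise gives > 60000 nM in this assay, also a limit. All three sit at the limit of > 60000 nM in this assay, at which 3 of the 3 values shown sit. Compound 4, `CS(=O)(=O)c1ccc(C(=O)N2CCC(C(=O)N(Cc3ccccc3)Cc3ccccc3)CC2)cc1[N+](=O)[O-]`, differs from compound 1 by benzyl in place of phenyl on an amide-type nitrogen. Within the data shown here, no measured step of this kind exists here, so the expectation rests on the limits alone. For compound 4 the expected step that the limit leaves unreadable from compound 1 to compound 4 is none beyond the scatter. Compound 4 is estimated at 100000 nM, within 30000 nM to 300000 nM.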

Compound 4, half-maximal inhibitory concentration: > 60000 nM
Compound 4: no number, only a limit; the forecaster's own chance of this, stated with the estimate: 85%; the middle value does not contradict the limit.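

Compound 1 and compound 4 both give only a limit, so benzyl in place of phenyl yields no readable step: the limit of > 60000 nM in this assay, at which 4 of the 4 values shown sit.

The compounds shown leave open which structural change, if any, would give a measurable number in this assay.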